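A Chlorine Added to the Phenyl Ring of Compound 1

This account rests on a few compounds, and the source may have more. Where it says the series, first, only, none or still open, it means among the compounds named here.

Compound 1 `COc1cc(CSc2cc(Cl)c(-c3nnc(-c4ccccc4)s3)cc2S(=O)(=O)NC(=N)NO)cc(OC)c1OC` was tested in a functional assay on M14 cells (Homo sapiens) (on this read-out higher numbers stand for weaker inhibition of growth and lower numbers for stronger inhibition of growth), where compound 1 gives 4070 nM. Among the three measured compounds this is the highest number. Compound 2 `COc1cc(CSc2cc(Cl)c(-c3nc(-c4ccc(Cl)cc4)no3)cc2S(=O)(=O)NC(=N)NO)cc(OC)c1OC` gives 2190 nM, and the step of a 1.9-fold lower number from compound 1 to compound 2 (0.27 log units; within the scatter) stays within the scatter. Going by the values given here, compound 3 `N=C(NO)NS(=O)(=O)c1cc(-c2nnc(-c3ccc(Cl)cc3)s2)c(Cl)cc1SCc1ccccc1` gives 1680 nM; its gap from compound 1 lies beyond the scatter, though no single-point step joins these two.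

Compound 4 `COc1cc(CSc2cc(Cl)c(-c3nnc(-c4ccc(Cl)cc4)s3)cc2S(=O)(=O)NC(=N)NO)cc(OC)c1OC` differs from compound 1 in one place: chloro in place of hydrogen on an aromatic carbon. Among the compounds with values here, the only measured step that bears on this is the one from compound 1 to compound 2, which brings in the same chlorine but also exchanges the five-membered ring, and it moved the number only within the scatter. Compound 3 also carries the 5-(4-chlorophenyl)-1,3,4-thiadiazol-2-yl group but differs elsewhere, so its value is only a loose hint toward a lower number. A step within the scatter, if anything downward, is therefore expected. Compound 4 is estimated at 2800 nM, between 1400 nM and 5600 nM. The expected step is a 1.5-fold lower number from compound 1 to compound 4 (0.16 log units; within the scatter).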

Compound 4, concentration for 50% growth inhibition: 40700 nM
Compound 4: middle estimate off by 15-fold (1.16 log units), on the low side; measured number outside the range, above it.
By their numbers in this assay, from the lowest: compounds 3, 2 and 1 (each within the scatter of the next, the first and the last beyond it); then compound 4.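

On this phenyl ring, a single chlorine para to a large group is far from a silent change in this assay: it gives a 10-fold higher number from compound 1 to compound 4 (1.00 log units; beyond the scatter), so growth inhibition weakens. The effect also depends on the rest of the molecule, since compound 4 is set apart from two other chlorine-bearing compounds by single changes elsewhere: 3,4,5-trimethoxyphenyl in place of phenyl gives a 24-fold higher number from compound 3 to compound 4 (1.38 log units; beyond the scatter), and the 5-(4-chlorophenyl)-1,3,4-thiadiazol-2-yl group in place of the 3-(4-chlorophenyl)-1,2,4-oxadiazol-5-yl group gives a 19-fold higher number from compound 2 to compound 4 (1.27 log units; beyond the scatter). Nothing available explains why this combination of groups stands so far from the others.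

On these data alone, it remains open whether a fluoro or a methoxy group on the same aromatic carbon would behave like chloro. Also open, as far as these compounds go, is whether chloro in place of hydrogen would bring a step of similar size with plain phenyl on the chain carbon, as in compound 3.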